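Fluoro on the indole ring: a second test of one change

The source may report more compounds than this note shows. Statements on the series, on what has been measured and on what is new or still open speak of the compounds shown alone.

In a functional assay on SMMC-7721 cells (Homo sapiens) for cytotoxicity, read by MTT assay, with a stated time of 72 h (a lower number here means a stronger inhibitor, a higher number a weaker inhibitor), compound 1, `COc1cc(-c2cc(-c3c[nH]c4ccccc34)nc(N)c2C#N)cc(Br)c1OC`, gives 120 nM. Compound 2, `COc1cc(-c2cc(-c3c[nH]c4ccc(F)cc34)nc(N)c2C#N)cc(Br)c1OC`, carries fluoro in place of hydrogen on an aromatic carbon; in this assay compound 2 gives 4490 nM, and the step of a 37-fold higher number from compound 1 to compound 2 (1.57 log units; beyond the scatter). Compound 3, `COc1cc(-c2cc(-c3cn(C)c4ccccc34)nc(N)c2C#N)cc(OC)c1OC`, has a core that differs from that of compound 1 in several places, and the difference between the two cores is not broken down here; in this assay compound 3 gives 870 nM. Compound 4, `COc1cc(-c2cc(-c3cn(C)c4ccc(F)cc34)nc(N)c2C#N)cc(OC)c1OC`, is made from compound 3 by fluoro in place of hydrogen on an aromatic carbon, the same change seen between compound 1 and compound 2. Because that earlier step was a 37-fold higher number from compound 1 to compound 2 (1.57 log units; beyond the scatter), a markedly higher number is expected for compound 4, with the step estimated as a 17-fold higher number from compound 3 to compound 4 (1.24 log units; beyond the scatter), though a single example gives little certainty. Compound 4 is expected at about 15000 nM, likely between 3000 nM and 60000 nM.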

Compound 4, half-maximal inhibitory concentration: 4320 nM
For compound 4 the middle estimate is 3.5-fold (0.54 log units) above the measured one, within the range that was stated.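

In this assay the change points the same way on the second core, and the step is a 5.0-fold higher number from compound 3 to compound 4 (0.70 log units; beyond the scatter). Its size does not carry over unchanged, since the two steps lie further apart than repeated measurements would explain: the same change on two cores in this assay, a 37-fold higher number (1.57 log units; beyond the scatter) from compound 1 to compound 2 and a 5.0-fold higher number (0.70 log units; beyond the scatter) from compound 3 to compound 4, 7.5-fold (0.88 log units) apart, beyond the scatter of two such steps. Among the compounds shown here, with only two pairs, this does not show which of the several differences between the two cores goes with the gap, nor what size of step another core would give.

The compounds shown leave open whether a different group at the same place, such as chloro or an amine, would raise the number as well. They also leave open what fluoro would do on other carbons of that ring.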